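The compounds below may be only part of what the source reports. "The series", "measured", "known", "first", "only" and "open" are said of these compounds alone.

Among the compounds with values here, in a functional assay on HeLa cells (Homo sapiens) for cytotoxicity, read by sulforhodamine B assay, with a stated time of 48 h (on this read-out higher numbers stand for weaker inhibition of growth and lower numbers for stronger inhibition of growth), compound 1 (`CCn1cc(-c2nc3ccccc3[nH]2)c(=O)c2cc(F)c(N3CCNCC3)nc21`) gives 6400 nM and has the highest number of the three compounds measured so far, which makes it the weakest of them, beyond the scatter from both others. In this assay compound 2 (`CCn1cc(-c2nc3ccc(Cl)cc3[nH]2)c(=O)c2cc(F)c(N3CCNCC3)cc21`) gives 1200 nM and compound 3 (`CCn1cc(-c2nc3ccc([N+](=O)[O-])cc3[nH]2)c(=O)c2cc(F)c(N3CCNC(C)C3)c(F)c21`) gives 1400 nM as its reading, and these two values lie within the scatter of each other.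

Compound 4 (`CCn1cc(-c2nc3ccc(N)cc3[nH]2)c(=O)c2cc(F)c(N3CCNCC3)nc21`) keeps the core of compound 1 and makes one change, amino in place of hydrogen on an aromatic carbon. Within the data shown here, no two measured compounds differ in one place only, so the size of this step cannot be read directly from the data. Compound 2 at 1200 nM and compound 3 at 1400 nM each carry a group on the ring that takes the amino in compound 4, and both stand lower than compound 1 does. Both also differ from compound 1 elsewhere, so they offer only weak guidance. The estimated step of a 2.1-fold lower number from compound 1 to compound 4 (0.33 log units; beyond the scatter) is a modest one toward stronger inhibition of growth, close to the edge of the scatter. For compound 4 the estimated value is 3000 nM with an expected range from 900 nM to 9000 nM in this assay when it is measured.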

Compound 4, concentration for 50% growth inhibition: > 10000 nM
Compound 4 ended at the assay's limit (the forecaster's own chance of this, stated with the estimate: 5%); middle value at least 3.3-fold (0.52 log units) away from the limit.
By their numbers in this assay, from the lowest: compounds 2 and 3 (each within the scatter of the next); then compound 1. At a limit, above all of these: compound 4.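

In this assay compound 4 gives > 10000 nM, which is a limit of the assay and not a number: the limit of > 10000 nM in this assay, at which 1 of the 4 values shown sits.

Within the data shown here, this gives the first step that can be read for a single change, and it concerns the six-membered aromatic ring of carbon only, at the place meta to a fused ring and para to a fused ring: amino in place of hydrogen on an aromatic carbon gives an at least 1.5-fold higher number from compound 1 to compound 4 (0.19 log units; that floor lies within the scatter). On the core of compound 1, then, this change brought no stronger inhibition of growth, although only a floor is known for the step, so its true size and whether it exceeds the scatter remain undetermined.

Steps to compound 2 and compound 3 cannot be read, as each differs from compound 1 in more than one place, so the effect of their ring groups at this position remains unresolved. Also open, on these data alone, is what a methoxy group, a hydroxyl group or a carboxylic acid in place of the amino would give on the core of compound 1.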